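The source may hold more compounds than are shown below. What is called first, only, known or untested is meant among the compounds shown, and "the series" means these compounds.

Compound 1 `O=C(N[C@@H]1C[C@H](C(=O)NO)N(S(=O)(=O)c2ccc(Cl)c(Cl)c2)C1)c1cccs1` stands highest of the two numbered entries in an assay on isolated protein for inhibition of matrix metalloproteinase-9 (Homo sapiens), read by fluorescence, with stated times of 5 min and 30 min, tested at 5 uM (on this read-out lower numbers stand for less inhibition and higher numbers for more inhibition at the one concentration tested (going by the name of the read-out)), where compound 1 reaches 95%. Compound 3 `O=C(NO)[C@H]1C[C@@H](n2cc(-c3ccccc3)nn2)CN1S(=O)(=O)c1ccc(Cl)c(Cl)c1` gives 83% in this assay, a gap beyond the usual scatter. Among the measured compounds shown here, compound 2 `O=C(N[C@H]1C[C@H](C(=O)NO)N(S(=O)(=O)c2ccc(Cl)c(Cl)c2)C1)c1cccs1` is reported in this assay as "not active" (no number reported), and its only difference from compound 1 is the fact that compounds 1 and 2 differ only in the configuration as drawn. Compound 4 `O=C(NO)[C@H]1C[C@@H](OCc2ccccc2)CN1S(=O)(=O)c1ccc(Cl)c(Cl)c1` is not yet measured; it differs from compound 1 by benzyloxy in place of ((thiophen-2-yl)carbonyl)amino on a saturated ring carbon. For the measured compounds named here, since no single-change step has been measured, the step is expected to be a modest loss, probably a little beyond the scatter, as compound 3 showed with 83% after its own change on the same ring carbon. The expected step of a number 17 percentage points lower from compound 1 to compound 4 (beyond the scatter) leads to an estimate for compound 4 of 78%, within 55% to 95%.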

Compound 4, a percentage reported as inhibition, at one concentration (the size of the read-out at that concentration, not a potency): 97%
Compound 4: middle estimate off by 19 percentage points, on the low side; the whole stated range lies below it.
By their numbers in this assay, from the lowest: compound 3; then compounds 1 and 4 (each within the scatter of the next).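

In this assay, benzyloxy in place of ((thiophen-2-yl)carbonyl)amino on this saturated ring carbon gives a number 2 percentage points higher from compound 1 to compound 4 (within the scatter). The position therefore accepts a six-membered aromatic ring of carbon only in place of a five-membered aromatic ring with one hetero atom, and the reading holds without the hydrogen-bond donor that leaves. Nothing shown explains why the two groups read alike. The compounds shown leave open whether an amine or a carboxylic acid on this carbon would keep the reading. Also open, going by these compounds, is whether benzyloxy depends on the configuration as drawn.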